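Extending the Chain on a Shared Core

The compounds below may be only part of what the source reports. "The series", "measured", "known", "first", "only" and "open" are said of these compounds alone.

Compound 2 `CCCCCNc1nc(SCCCC)nc2ncccc12` and compound 1 `CCCCCCNc1nc(SCC)nc2ncccc12` share one core and differ in the length of their two chains. In a functional assay on HT-29 cells (Homo sapiens) for cytotoxicity, read by neutral red uptake, with a stated time of 72 h (on this read-out higher numbers stand for weaker inhibition and lower numbers for stronger inhibition), compound 2 gives 12600 nM, while compound 1 gives 22500 nM; these two numbers lie within the scatter of each other, so neither compound can be set apart from the other on this read-out. Compound 3 `CCCCCCNc1nc(SCCCC)nc2ncccc12` has not yet been measured in this assay. It differs from compound 2 by methyl in place of hydrogen on a saturated chain carbon, five bonds along the chain from a nitrogen on an aromatic ring. Going by the values given here, no step between two measured compounds that differ in one place alone is available here, so nothing in the measured pair fixes the size of such a change. With only compound 1 and compound 2 to go on, and their values so close, the step this estimate implies is expected to be small, a 1.1-fold lower number from compound 2 to compound 3 (0.06 log units; within the scatter), in no direction that reaches beyond the scatter. Compound 3 is therefore expected to give 11000 nM in this assay, with a range from 5000 nM to 25000 nM.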

Compound 3, half-maximal inhibitory concentration: 2800 nM
The estimate for compound 3 lay 3.9-fold (0.59 log units) above the measured number; measured number below the stated range.
By their numbers in this assay, from the lowest: compound 3; then compounds 2 and 1 (each within the scatter of the next).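

The result shows that the chain matters at both places once each is changed alone. In this assay, methyl in place of hydrogen on a saturated chain carbon, five bonds along the chain from a nitrogen on an aromatic ring, gives a 4.5-fold lower number from compound 2 to compound 3 (0.65 log units; beyond the scatter), and ethyl in place of hydrogen on a saturated chain carbon, two bonds along the chain from a sulfur, gives an 8.0-fold lower number from compound 1 to compound 3 (0.91 log units; beyond the scatter); both steps lie beyond the scatter, which the earlier pair, differing in two places at once, could not reveal. No measurement is available that would account for either step.

Each place rests on a single step, so the compounds shown do not tell whether a longer chain at either place would take the number lower still, or whether the trend would stop or turn. They also leave open how a different group, such as an amine or a carboxylic acid, would behave at these places on the shared core.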